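Pyridin-2-yl for Methylphenyl on the Ketone of Compound 1

This account rests on a few compounds, and the source may have more. Where it says the series, first, only, none or still open, it means among the compounds named here.

Measured compounds:
- compound 1, `Cc1ccc(C(=O)CC2CC(=O)N(c3ccc(S(N)(=O)=O)cc3)C2=O)cc1`: 860 nM
- compound 2, `CC(=O)CC1CC(=O)N(c2ccccc2)C1=O`: 62400 nM

The work was read out in an assay on cells (1-87 tumor cell line) for inhibition of Polyunsaturated fatty acid 5-lipoxygenase (Homo sapiens), with a stated time of 5 min; on this read-out lower numbers stand for stronger inhibition and higher numbers for weaker inhibition. Of the two measured compounds, compound 1 gives the lower number, 860 nM, while compound 2 gives a distant companion to that, 62400 nM. Compound 2 differs from compound 1 in more than one place, so their gap, which lies beyond the scatter, cannot be assigned to a single change; the two values only show that compound 1 is the stronger of the pair in this assay.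

Compound 3, `NS(=O)(=O)c1ccc(N2C(=O)CC(CC(=O)c3ccccn3)C2=O)cc1`, is not yet measured. It departs from compound 1 by one change: pyridin-2-yl in place of 4-methylphenyl on a carbonyl carbon. The carbonyl and the shared core are untouched.

Going by the values given here, with no measured step for this kind of exchange, the expectation rests on compound 1 alone. Compound 3 is expected to give 1500 nM, with a range from 400 nM to 6000 nM. The step of a 1.7-fold higher number from compound 1 to compound 3 (0.24 log units; within the scatter) is the size expected, a modest move toward a weaker number that may not exceed the scatter.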

Compound 3, half-maximal inhibitory concentration: 810 nM
Estimate against measurement, compound 3: 1.9-fold (0.27 log units) above; the measured number falls inside the stated range.
By their numbers in this assay, from the lowest: compounds 3 and 1 (each within the scatter of the next); then compound 2.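

In this assay, pyridin-2-yl in place of 4-methylphenyl on a carbonyl carbon gives a 1.1-fold lower number from compound 1 to compound 3 (0.03 log units; within the scatter), so compound 1 and compound 3 cannot be told apart on this read-out. This position therefore accepts the exchange of an aromatic ring of carbon only for an aromatic ring with one hetero atom, without a step that rises beyond the scatter, which the pair of compound 1 and compound 2, differing in more than one place, could not show. No measurement bears on why these two groups read alike.

The compounds shown leave open how an unsubstituted phenyl, a pyridin-3-yl or a pyridin-4-yl would read on this carbonyl carbon, and whether a saturated ring such as cyclohexyl or a ring carrying a carboxylic acid would hold the number of compound 1 at 860 nM. Going by these compounds alone, they also leave open how the large gap between compound 1 and compound 2 divides between the group on the carbonyl carbon and the sulfonamide, since no single-place step separates the two.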